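The source may hold more compounds than are shown below. What is called first, only, known or untested is meant among the compounds shown, and "the series" means these compounds.

Three compounds built on the core of compound 1 `NC(=S)Nc1cccc(OCCCCCOc2ccccc2)c1` have been measured in an ADME assay on Ava5 cells (Homo sapiens) for cytotoxicity; a higher number here means that more compound is tolerated, a lower number that less compound is tolerated. Compound 1 gives only a limit in this assay, > 50000 nM. Compound 2 `CC(CCOc1ccccc1)CCOc1cccc(NC(N)=S)c1` likewise gives only a limit in this assay, > 50000 nM. Compound 3 `NC(=S)Nc1cccc(OCCCCCOc2cccc(Oc3ccccc3)c2)c1` gives a number in this assay, 18000 nM. The step of an at least 2.7-fold lower number from compound 1 to compound 3 (0.44 log units; beyond the scatter) is therefore readable. The step that the two limits leave unreadable from compound 1 to compound 2 cannot be read because the limit of > 50000 nM in this assay, at which 2 of the 3 values shown sit, holds both of its ends. Compound 2 thus stands at the ceiling of this assay, alongside compound 1, with only compound 3 giving a number at all.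

Compound 4 `CC(C)(CCOc1ccccc1)CCOc1cccc(NC(N)=S)c1` differs from compound 2 by methyl in place of hydrogen on a saturated chain carbon bound to three saturated chain carbons. Among the compounds with values here, the only measured step that bears on this change is a step that the two limits leave unreadable from compound 1 to compound 2, which is itself a methyl entering on a saturated chain carbon, and its size is not readable. Within the data shown here, no other measured step involves a change of this kind, and the measured step of an at least 2.7-fold lower number from compound 1 to compound 3 (0.44 log units; beyond the scatter) concerns a different group on a different part of the molecule. The expectation is therefore that compound 4 behaves as compound 2 does and that the step that the limit leaves unreadable from compound 2 to compound 4 stays within the scatter. Compound 4 is accordingly estimated at 60000 nM, between 25000 nM and 150000 nM, and most likely again reported only as a limit.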

Compound 4, half-maximal cytotoxic concentration: 13000 nM
Compound 4: middle estimate off by 4.6-fold (0.66 log units), on the high side; measured number below the stated range.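

Methyl in place of hydrogen on a saturated chain carbon bound to three saturated chain carbons gives, in this assay, an at least 3.8-fold lower number from compound 2 to compound 4 (0.58 log units; beyond the scatter). Within the data shown here, a change of one carbon in the chain is thus enough to bring a compound off the limit, which among the earlier compounds only phenoxy in place of hydrogen on an aromatic carbon had done, with an at least 2.7-fold lower number from compound 1 to compound 3 (0.44 log units; beyond the scatter). The chain, which had shown nothing readable so far, therefore counts in this assay, while the step between the two compounds that both stay at the limit still cannot be read, so what the first methyl on this chain contributes remains unknown: the limit of > 50000 nM in this assay, at which 2 of the 4 values shown sit.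

The compounds shown leave open whether an ethyl or a hydroxyl on the same chain carbon would also lower the number, and whether a shorter or longer chain would respond to the methyl in the same way. They also leave open what happens when this methyl and the phenoxy group stand together in one molecule.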